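The compounds below may be only part of what the source reports. "The series", "measured", "known", "first", "only" and "open" are said of these compounds alone.

Compound 3 `CCC1C(=O)N(C)c2cnc(-n3ccc4cc(C(=O)NC5CCCC5)ccc43)nc2N1c1ccn(C)n1` stands level with compound 1 `CCC1C(=O)N(C)c2cnc(-n3ccc4cc(C(N)=O)ccc43)nc2N1c1ccn(C)n1` at the top of the three numbers: in a functional assay on A549 cells (Homo sapiens) for antiproliferative activity, read by CCK-8 assay, with a stated time of 72 h (a lower number here means a stronger inhibitor of growth, a higher number a weaker inhibitor of growth), compound 3 gives 39500 nM, compound 1 gives 39500 nM, and the two are joined by no change at the digits printed from compound 1 to compound 3 (within the scatter). Compound 2 `CCC1C(=O)N(C)c2cnc(-n3ccc4cc(C(=O)NCC(C)C)ccc43)nc2N1c1ccn(C)n1` gives 19200 nM, reached through a 2.1-fold lower number from compound 1 to compound 2 (0.31 log units; beyond the scatter) and separated from the cyclopentyl compound by a 2.1-fold higher number from compound 2 to compound 3 (0.31 log units; beyond the scatter). Compound 4 `CCCNC(=O)c1ccc2c(ccn2-c2ncc3c(n2)N(c2ccn(C)n2)C(CC)C(=O)N3C)c1` brings (propyl in place of cyclopentyl on an amide-type nitrogen). Going by the values given here, the only steps that bear on this are the two around the isobutyl compound, a 2.1-fold lower number from compound 1 to compound 2 (0.31 log units; beyond the scatter) and a 2.1-fold higher number from compound 2 to compound 3 (0.31 log units; beyond the scatter), both modest, and they suggest that an open chain in place of the ring lowers the number somewhat. Compound 4 is therefore expected to show a 1.6-fold lower number from compound 3 to compound 4 (0.20 log units; within the scatter). The estimated value of compound 4 is 25000 nM, within 12000 nM to 50000 nM.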

Compound 4, concentration for 50% growth inhibition: "not active" (no number reported)
Compound 4: no number reported; no gap can be computed for the estimate.
By their numbers in this assay, from the lowest: compound 2; then compounds 1 and 3 (each within the scatter of the next).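

Going by these compounds alone, compound 4 is reported as "not active" in this assay with no number, so no step from compound 3 or any other compound to compound 4 can be read. Nothing available bears on this result. The compounds shown leave open how the propyl amide compares numerically with the isobutyl and cyclopentyl amides.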